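Truncating the aryl ether of compound 1 to hydroxymethyl

The source may hold more compounds than are shown below. What is called first, only, known or untested is meant among the compounds shown, and "the series" means these compounds.

Compound 1 `Cc1ccc(OCc2cn(-c3ccc(S(=O)(=O)N4CCc5ccccc5C4)cc3)nn2)cc1` sits at the top of what a functional assay on MOLT-3 cells (Homo sapiens) for cytotoxicity, read by MTT assay, with a stated time of 48 h (a higher number here means a weaker inhibitor, a lower number a stronger inhibitor), reports: compound 1 gives > 50 ug/mL, a limit rather than a number. Compound 2 `COc1cc2c(cc1OC)CN(S(=O)(=O)c1ccc(-n3cc(COc4ccc(C)cc4)nn3)cc1)CC2` also gives only a limit in this assay, > 50 ug/mL. Compound 3 `COc1cc2c(cc1OC)CN(S(=O)(=O)c1ccc(-n3cc(COc4ccccc4)nn3)cc1)CC2` gives > 50 ug/mL, again a limit. Within the data shown here, the one step within the set, a step that the two limits leave unreadable from compound 2 to compound 3, cannot be sized since the limit of > 50 ug/mL in this assay, at which 3 of the 3 values shown sit, covers every value measured. Compound 4 `O=S(=O)(c1ccc(-n2cc(CO)nn2)cc1)N1CCc2ccccc2C1` differs from compound 1 by hydrogen in place of 4-methylphenyl on an oxygen on a saturated carbon. Among the measured compounds shown here, no measured step covers this change, so no direction can be read from the series. In this assay, for the measured compounds named here, compound 4 is expected to stay at the limit, and a step that the limit leaves unreadable from compound 1 to compound 4 is estimated as no resolvable step. Compound 4 is estimated at 60 ug/mL, between 20 ug/mL and 200 ug/mL.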

Compound 4, half-maximal inhibitory concentration: > 50 ug/mL
Compound 4: only a limit was reported; the forecaster's own chance of this, stated with the estimate: 85%; the middle value lies beyond the limit too.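

In this assay compound 4 gives > 50 ug/mL, a limit, so no step can be read for its change from compound 1: the limit of > 50 ug/mL in this assay, at which 4 of the 4 values shown sit. The compounds shown leave open how far each lies beyond this limit, and whether any change to the series brings a measurable value.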